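Second methoxy on the benzyl ether of compound 2

The compounds below may be only part of what the source reports. "The series", "measured", "known", "first", "only" and "open" are said of these compounds alone.

Compound 2 `COc1cccc(COc2ccc(-c3cc(CN4CCN(Cc5ccc(C(F)(F)F)cc5)CC4)no3)cc2)c1` is a benzyl ether built on a shared core, and in a functional assay on Mahlavu cells (Homo sapiens) for antiproliferative activity, read by sulforhodamine B assay, with a stated time of 72 h (on this read-out higher numbers stand for weaker inhibition and lower numbers for stronger inhibition), compound 2 gives 1400 nM. Going by the values given here, that is the lowest of the two numbers measured so far; its nearest neighbour is compound 1 `N#Cc1ccccc1COc1ccc(-c2cc(CN3CCN(Cc4ccc(C(F)(F)F)cc4)CC3)no2)cc1`, which in this assay gives 3500 nM. Among the compounds with values here, the one step between measured compounds, a 2.5-fold lower number from compound 1 to compound 2 (0.40 log units; beyond the scatter), exchanges a 2-cyanophenyl for a 3-methoxyphenyl on the saturated chain carbon bound to the ether oxygen.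

Compound 3 `COc1cc(COc2ccc(-c3cc(CN4CCN(Cc5ccc(C(F)(F)F)cc5)CC4)no3)cc2)cc(OC)c1` differs from compound 2 by methoxy in place of hydrogen on an aromatic carbon, that is, a methoxy in place of hydrogen on an aromatic carbon of the six-membered carbon ring, meta to a large group and meta to the methoxy already present, turning 3-methoxyphenyl into 3,5-dimethoxyphenyl. Within the data shown here, no measured step adds a second methoxy to this ring; the step from compound 1 to compound 2 concerns a different exchange and cannot be carried over directly. The step from compound 2 to compound 3 is therefore expected to stay within the usual scatter, as a 1.2-fold lower number from compound 2 to compound 3 (0.07 log units; within the scatter). Compound 3 is estimated to give 1200 nM in this assay, within a range from 500 nM to 3000 nM.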

Compound 3, half-maximal inhibitory concentration: 4300 nM
For compound 3 the middle estimate is 3.6-fold (0.55 log units) below the measured one; the measured number lies above the stated range.
By their numbers in this assay, from the lowest: compound 2; then compounds 1 and 3 (each within the scatter of the next).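

In this assay, the second methoxy is not a neutral addition: on the aromatic carbon meta to the methoxy already present, turning 3-methoxyphenyl into 3,5-dimethoxyphenyl gives a 3.1-fold higher number from compound 2 to compound 3 (0.49 log units; beyond the scatter). The earlier exchange showed only that 3-methoxyphenyl outperforms 2-cyanophenyl, whereas this result shows that adding more methoxy to the ring does not extend that gain, since the step to the dimethoxy compound, a 1.2-fold higher number from compound 1 to compound 3 (0.09 log units; within the scatter), leaves no difference that can be told from the scatter. Nothing available here accounts for the loss of inhibition that comes with the added methoxy.

On these data alone, what stays open is whether this loss belongs to methoxy in particular or would follow any group placed on this carbon, a question that a fluorine, a chlorine, a hydroxy or an ethoxy at the same place could begin to answer. It is also unknown whether the same penalty would hold on a ring carrying a different first group, since the second methoxy has been seen here only alongside the first.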